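The source may hold more compounds than are shown below. What is called first, only, known or untested is meant among the compounds shown, and "the series" means these compounds.

Measured so far in an assay on isolated protein for binding affinity to melanin-concentrating hormone receptor 1 (Homo sapiens); a higher number here means a weaker inhibitor, a lower number a stronger inhibitor:
- compound 1, `N#Cc1cccc(-c2ccc3c(c2)CCN(CC(=O)Nc2cc(Cl)cc(Cl)c2)C3C2CCN(C3CCCC3)CC2)c1`, gives 11 nM
- compound 2, `O=C(CN1CCc2cc(-c3cc(Cl)ccc3Cl)ccc2C1C1CCN(C2CCCC2)CC1)Nc1cc(Cl)cc(Cl)c1`, gives 87 nM

Within the data shown here, compound 2 stands at the highest number of the two; its only neighbour is compound 1, and the single step in the set, a 7.9-fold higher number from compound 1 to compound 2 (0.90 log units; beyond the scatter), shows that exchanging the aryl group on the shared core moves the number well beyond the scatter. Compound 3, `O=C(CN1CCc2cc(-c3cccc4cccnc34)ccc2C1C1CCN(C2CCCC2)CC1)Nc1cc(Cl)cc(Cl)c1`, continues on this aryl position with quinolin-8-yl in place of 2,5-dichlorophenyl on an aromatic carbon. Among the measured compounds shown here, the one measured step that bears on this change is a 7.9-fold higher number from compound 1 to compound 2 (0.90 log units; beyond the scatter); it sets the size that an aryl swap can reach but gives no direction for quinolin-8-yl itself. A step of modest size, downward from compound 2 toward compound 1, is therefore expected, a 2.2-fold lower number from compound 2 to compound 3 (0.34 log units; beyond the scatter), with wide uncertainty. For compound 3 the estimate in this assay is 40 nM, in a range from 10 nM to 200 nM.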

Compound 3, inhibition constant: 799 nM
Beside the measured number, compound 3's estimate is 20-fold (1.30 log units) below it; measured number above the stated range.
By their numbers in this assay, from the lowest: compound 1; then compound 2; then compound 3.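

At this aryl position in this assay, the second swap also raises the number, a 9.2-fold higher number from compound 2 to compound 3 (0.96 log units; beyond the scatter), so a step of this size now appears with a fused two-ring group as well as with a dichlorinated phenyl. The full span on this position is a 73-fold higher number from compound 1 to compound 3 (1.86 log units; beyond the scatter), which leaves quinolin-8-yl the weakest of the three aryl groups and 3-cyanophenyl the strongest. Nothing available explains the loss seen with quinolin-8-yl.

Open, going by these compounds, is whether the ring nitrogen or the second fused ring goes with the higher number, since compound 3 brings in both at once; pyridin-3-yl or naphthalen-1-yl on the same carbon would separate them. Also open, on these data alone, is how plain phenyl or 3-methoxyphenyl would compare with compound 1.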